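Aryl Swaps on a Triazole Amide: Cytotoxicity Outlook

The source may report more compounds than this note shows. Statements on the series, on what has been measured and on what is new or still open speak of the compounds shown alone.

compound 1 `COc1cc2c(Oc3ccc(NC(=O)c4nnn(-c5ccccc5Cl)c4C(F)(F)F)cc3F)ccnc2cc1OCCCN1CCN(C)CC1`: 240 nM
compound 2 `COc1cc2c(Oc3ccc(NC(=O)c4nnn(-c5ccc(C)cc5)c4C(F)(F)F)cc3F)ccnc2cc1OCCCN1CCN(C)CC1`: 370 nM

In a functional assay on A549 cells (Homo sapiens) for cytotoxicity, read by MTT assay, with a stated time of 72 h (on this read-out higher numbers stand for weaker inhibition and lower numbers for stronger inhibition), compound 1 gives 240 nM and compound 2 gives 370 nM. Compound 2 sits beside compound 1 on these two numbers, separated only by a 1.5-fold higher number from compound 1 to compound 2 (0.19 log units; within the scatter). Compound 3 `COc1cc2c(Oc3ccc(NC(=O)c4nnn(-c5ccc(F)c(F)c5)c4C(F)(F)F)cc3F)ccnc2cc1OCCCN1CCN(C)CC1` carries the change (3,4-difluorophenyl in place of 4-methylphenyl on an aromatic nitrogen). Among the measured compounds shown here, the only measured step that bears on this kind of swap is a 1.5-fold higher number from compound 1 to compound 2 (0.19 log units; within the scatter), which stayed within the scatter, so no shift beyond the scatter is expected in this assay. Compound 3 is estimated at 320 nM, between 130 nM and 800 nM. This amounts to an expected step of a 1.2-fold lower number from compound 2 to compound 3 (0.06 log units; within the scatter), within the scatter.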

Compound 3, half-maximal inhibitory concentration: 130 nM
Estimate against measurement, compound 3: 2.5-fold (0.39 log units) above; measured number inside the range.
By their numbers in this assay, from the lowest: compounds 3, 1 and 2 (each within the scatter of the next, the first and the last beyond it).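

The aryl group on this aromatic nitrogen can shift the number beyond the scatter in this assay: 3,4-difluorophenyl in place of 4-methylphenyl gives a 2.8-fold lower number from compound 2 to compound 3 (0.45 log units; beyond the scatter). In place of 2-chlorophenyl, the same group gives a 1.8-fold lower number from compound 1 to compound 3 (0.27 log units; within the scatter), so compound 1 and compound 3 cannot be ranked. Nothing available here explains the step.

Still open, as far as these compounds go, is whether both fluorines are needed, or whether a phenyl with a single fluorine would read the same. From the compounds shown here alone, how a plain phenyl, or a phenyl carrying an amine or a carboxylic acid, would behave at this nitrogen also remains unknown.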